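A few compounds are considered here, and "the series" means these few. Any claim that something is new, unique, unknown or untested is made for them only; others in the source may bear on it.

Compound 1 `COc1cccc(C(=O)n2c(-c3cn(C)c4ccccc34)nc3ccccc32)c1`: 15700 nM
Compound 2 `COc1ccc(C(=O)n2c(-c3cn(C)c4ccccc34)nc3ccccc32)cc1OC`: 10200 nM
Compound 3 `Cn1cc(-c2nc3ccccc3n2C(=O)c2cccc(Br)c2)c2ccccc21`: 63400 nM

In a functional assay on MCF7 cells (Homo sapiens) for inhibition, read by MTT assay, with a stated time of 24 h (a higher number here means a weaker inhibitor of growth, a lower number a stronger inhibitor of growth), compound 3 gives the highest number of the three, making it the weakest inhibitor so far: a 4.0-fold higher number from compound 1 to compound 3 (0.61 log units; beyond the scatter), and a 6.2-fold higher number from compound 2 to compound 3 (0.79 log units; beyond the scatter). Compound 4 `Cn1cc(-c2nc3ccccc3n2C(=O)c2cccc(Br)c2)c2cc(Br)ccc21` differs from compound 3 by bromo in place of hydrogen on an aromatic carbon, a bromo in place of hydrogen on an aromatic carbon. Among the measured compounds shown here, no measured step changes this ring. The closest guide is a 1.5-fold lower number from compound 1 to compound 2 (0.19 log units; within the scatter), which also replaces a hydrogen on an aromatic carbon, though on a different ring. A small step towards a lower number is therefore expected, probably not beyond the scatter. The expected change is a 1.5-fold lower number from compound 3 to compound 4 (0.18 log units; within the scatter). For compound 4 the estimated value is 42000 nM, with an expected range of 13000 nM to 110000 nM.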

Compound 4, concentration for 50% growth inhibition: 68200 nM
Beside the measured number, compound 4's estimate is 1.6-fold (0.21 log units) below it; measured number inside the range.
By their numbers in this assay, from the lowest: compounds 2 and 1 (each within the scatter of the next); then compounds 3 and 4 (each within the scatter of the next).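

Among the compounds shown here, the first measured change on this ring, a bromo in place of hydrogen on an aromatic carbon, gives a 1.1-fold higher number from compound 3 to compound 4 (0.03 log units; within the scatter) in this assay. At this position, then, the added bromine atom leaves the reading within the usual scatter, at least in a compound already carrying the 3-bromophenyl group. Nothing available explains this result.

Going by these compounds, it remains open whether the same bromo would behave this way in compound 1 or compound 2, which carry methoxy groups instead. On these data alone, it also remains open whether an amine or a carboxylic acid at this position would shift the number beyond the scatter.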